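Series notes: sulfonamide chain substituent and Caco-2 permeability

The source may hold more compounds than are shown below. What is called first, only, known or untested is meant among the compounds shown, and "the series" means these compounds.

Compound 3 `Cn1cncc1CN1CC(N(CCn2cccc2)S(=O)(=O)c2ccccn2)Cc2cc(C#N)ccc21` holds the highest number of the three measured in an ADME assay on Caco-2 cells (Homo sapiens) for permeability, in the apical to basolateral direction; on this read-out lower numbers stand for lower permeability and higher numbers for higher permeability: compound 3 gives 12.4 10^-6 cm/s. Compound 1 `Cn1cncc1CN1CC(N(CC2CCN(C(=O)CNC(=O)OC(C)(C)C)CC2)S(=O)(=O)c2ccccn2)Cc2cc(C#N)ccc21` gives 0.5 10^-6 cm/s and compound 2 `C=C(C)C(=O)N1CCC(CN(C2Cc3cc(C#N)ccc3N(Cc3cncn3C)C2)S(=O)(=O)c2ccccn2)CC1` gives 0.5 10^-6 cm/s; no change at the digits printed from compound 1 to compound 2 (within the scatter). Compound 4 `Cn1cncc1CN1CC(N(CC2CCN(C(=O)C(C)(C)C)CC2)S(=O)(=O)c2ccccn2)Cc2cc(C#N)ccc21` differs from compound 3 by 1-((tert-butyl)carbonyl)piperidin-4-yl in place of (1H-pyrrol-1-yl)methyl on a saturated chain carbon bound to a sulfonamide nitrogen. The step that bears on this is a 25-fold higher number from compound 2 to compound 3 (1.39 log units; beyond the scatter), since compound 4 restores a piperidin-4-yl amide on that chain carbon, and no change at the digits printed from compound 1 to compound 2 (within the scatter) indicates the amide group itself has little weight. A large drop in this assay is therefore expected, broadly reversing the gain seen on going to compound 3. For compound 4 the expected step is a 21-fold lower number from compound 3 to compound 4 (1.32 log units; beyond the scatter). Compound 4 is estimated at 0.6 10^-6 cm/s, with a range from 0.25 10^-6 cm/s to 1.5 10^-6 cm/s.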

Compound 4, apparent permeability: 0.5 10^-6 cm/s
Compound 4: middle estimate off by 1.2-fold (0.08 log units), on the high side; low and high end bracket the measured number.
By their numbers in this assay, from the lowest: compounds 1, 2 and 4 (each within the scatter of the next); then compound 3.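

In this assay the change on the saturated chain carbon bound to a sulfonamide nitrogen now reads in both directions, with a 25-fold lower number from compound 3 to compound 4 (1.39 log units; beyond the scatter) matching the earlier gain in size. The group on the carbonyl carbon carries little weight among the three amides shown: tert-butyl gives no change at the digits printed from compound 2 to compound 4 (within the scatter) and no change at the digits printed from compound 1 to compound 4 (within the scatter). Nothing available explains the difference between the two chain substituents.

Going by these compounds, it remains open whether a free piperidine amine, a carboxylic acid or a plain longer alkyl chain on that carbon would sit with compound 3 or with the three amides. The shown compounds also do not separate the contribution of the 1H-pyrrol-1-yl ring from that of the shorter chain.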